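Swapping nitro for methoxy on a weakly active urea ester

The compounds below may be only part of what the source reports. "The series", "measured", "known", "first", "only" and "open" are said of these compounds alone.

Measured so far:
- compound 1, `CC(=O)c1cccc(NC(=O)Nc2ccc(OC(=O)c3cc4cc([N+](=O)[O-])ccc4s3)cc2)c1`, 61500 nM
- compound 2, `O=C(Nc1ccc(OC(=O)c2ccc(Cl)cc2)cc1)Nc1ccc(Cl)c(C(F)(F)F)c1`, 6620 nM
- compound 3, `O=C(Nc1ccccc1)Nc1ccc(OC(=O)c2ccc([N+](=O)[O-])cc2)cc1`, 120000 nM

All three were tested in a functional assay on A549 cells (Homo sapiens) for antiproliferative activity, read by MTT assay, with a stated time of 48 h; a higher number here means a weaker inhibitor, a lower number a stronger inhibitor. Compound 3 gives the highest number of the three. Its nearest neighbour is compound 1, and the gap between them lies within the usual scatter of repeated measurements, so no order between compound 3 and compound 1 can be read from these two values. Compound 2, with 6620 nM, stands well beyond the scatter from compound 3, so compound 2 is clearly the stronger inhibitor of that pair.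

Compound 4, `COc1ccc(C(=O)Oc2ccc(NC(=O)Nc3ccccc3)cc2)cc1`, has not been measured. It differs from compound 3 in one place: methoxy in place of nitro on an aromatic carbon. Going by the values given here, no measured pair in this set shows what this exchange does, so the direction of the step is not known from the data. Given that compound 3 sits at the weak end of the measured range, the step from compound 3 to compound 4 is expected to be small, a 1.2-fold lower number from compound 3 to compound 4 (0.08 log units; within the scatter), with no firm direction beyond the scatter. Compound 4 is therefore estimated to give about 100000 nM in this assay, within a range from 30000 nM to 300000 nM.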

Compound 4, half-maximal inhibitory concentration: 60200 nM
The estimate for compound 4 lay 1.7-fold (0.22 log units) above the measured number; the range from low to high includes it.
By their numbers in this assay, from the lowest: compound 2; then compounds 4, 1 and 3 (each within the scatter of the next).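

Going by these compounds alone, compound 3 and compound 4 form the first pair in this set that differs in only one place, so they give the first direct reading of this position on an aromatic carbon, para to a large group. In this assay, the exchange of 4-nitrophenyl to 4-methoxyphenyl gives a 2.0-fold lower number from compound 3 to compound 4 (0.30 log units; within the scatter), so these two values cannot be ordered, even though nitro and methoxy differ in their atoms and in their hydrogen-bond acceptors. At this position and on this shared core, the exchange therefore shows no measurable effect on antiproliferative activity, and no measured property of either compound is available to account for that result.

A single exchange cannot show whether this position tolerates every group, and an amine, a carboxylic acid or a longer chain such as butoxy might still move the number beyond the scatter. On these data alone, it also remains open whether the same exchange would behave in the same way on a different core, such as the core of compound 1, which carries its nitro group in a different setting.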